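The source may report more compounds than this note shows. Statements on the series, on what has been measured and on what is new or still open speak of the compounds shown alone.

Three compounds have been measured in a functional assay on CHO cells with adenosine receptor A1 (Homo sapiens) as the target, read by cAMP accumulation and immunoassay, with a stated time of 6 min, tested at 0.1 uM; on this read-out higher numbers stand for a weaker effect at the one concentration tested and lower numbers for a stronger effect:

Compound 1, `Nc1scc(CN2CCN(c3cccc(C(F)(F)F)c3)CC2)c1C(=O)c1ccc(Cl)cc1`, gives -30%.
Compound 2, `Nc1scc(CN2CCN(c3ccc(OC(F)(F)F)cc3)CC2)c1C(=O)c1ccc(Cl)cc1`, gives -13%.
Compound 3, `Nc1scc(CN2CCC(c3ccc(Cl)cc3)CC2)c1C(=O)c1ccc(Cl)cc1`, gives -2.3%.

Among these three numbers compound 2 stands second highest: compound 3 lies a little higher, beyond the scatter, and compound 1 lies lower, also beyond the scatter. Compound 4, `Nc1scc(CN2CCN(c3cccc(F)c3F)CC2)c1C(=O)c1ccc(Cl)cc1`, has not yet been measured. It differs from compound 2 in one place only: 2,3-difluorophenyl in place of 4-(trifluoromethoxy)phenyl on an amine nitrogen in a ring.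

Among the measured compounds shown here, the one measured step that speaks to this kind of change is the swap of the group on the ring nitrogen between compound 1 and compound 2, where the number moved by a number 17 percentage points higher from compound 1 to compound 2 (beyond the scatter). So exchanging that group can shift the read-out by a modest amount, in either direction, and nothing measured here tells which way a 2,3-difluorophenyl group will push it. A step of similar size or smaller is therefore expected, with the direction open, giving a number 2 percentage points lower from compound 2 to compound 4 (within the scatter) as the estimated change. For compound 4 the expected value in this assay is -15%, with a range from -35% to 5%.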

Compound 4, a percentage reported as activity, at one concentration (the size of the read-out at that concentration, not a potency): -5.2%
Beside the measured number, compound 4's estimate is 9.8 percentage points below it; low and high end bracket the measured number.
By their numbers in this assay, from the lowest: compound 1; then compounds 2, 4 and 3 (each within the scatter of the next, the first and the last beyond it).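

On the ring nitrogen, 2,3-difluorophenyl and 4-(trifluoromethoxy)phenyl cannot be told apart in this assay: the exchange gives a number 7.8 percentage points higher from compound 2 to compound 4 (within the scatter), even though the entering group has fewer heavy atoms and no oxygen. Set against 3-(trifluoromethyl)phenyl, the same group gives a step that can be read, a number 24.8 percentage points higher from compound 1 to compound 4 (beyond the scatter), so among the three groups compared at this position only the 3-(trifluoromethyl)phenyl of compound 1 stands apart. Nothing available here explains why that one group differs from the other two.

From the compounds shown here alone, what a plain phenyl ring, a methoxyphenyl or a benzyl group would do on this nitrogen remains open. Going by these compounds, each number also comes from a single concentration, so how these compounds would compare across a range of concentrations is unknown.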